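A few compounds are considered here, and "the series" means these few. Any claim that something is new, unique, unknown or untested is made for them only; others in the source may bear on it.

In a functional assay on MCF7 cells (Homo sapiens) for antiproliferative activity, read by sulforhodamine B assay, with a stated time of 48 h (a lower number here means a stronger inhibitor, a higher number a weaker inhibitor), compound 1 `O=C1NCCN1c1ccc(S(=O)(=O)Nc2ccc(C3CCCCC3)cc2)cc1` gives > 1000 nM, which is a limit of the assay and not a number. For the measured compounds named here, compound 2 `O=C1NCCN1c1ccc(S(=O)(=O)Nc2ccc(OC(F)F)cc2)cc1` gives 760 nM, the only true number so far. Compound 3 `CCCCCc1ccc(NS(=O)(=O)c2ccc(N3CCNC3=O)cc2)cc1` has pentyl in place of difluoromethoxy on an aromatic carbon. Going by the values given here, one measured step bears on this change, an at least 1.3-fold lower number from compound 1 to compound 2 (0.11 log units; that floor lies within the scatter), where difluoromethoxy replaced cyclohexyl, so it offers only weak guidance. A small shift towards a higher number is therefore expected, giving an estimated 1.2-fold higher number from compound 2 to compound 3 (0.07 log units; within the scatter). For compound 3 the expected value is 900 nM, with an estimated range from 300 nM to 3000 nM.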

Compound 3, half-maximal inhibitory concentration: > 1000 nM
Compound 3: only a limit was reported; the forecaster's own chance of this, stated with the estimate: 40%; at least 1.1-fold (0.04 log units) between middle value and limit.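

Pentyl in place of difluoromethoxy gives an at least 1.3-fold higher number from compound 2 to compound 3 (0.11 log units; that floor lies within the scatter), so only a floor on this change is known. In this assay compound 3 gives > 1000 nM, which is a limit of the assay and not a number, and its step with compound 1 cannot be read. With a carbon-only group at this position, whether cyclohexyl or pentyl, no true number appears, and compound 2 remains the only compound with one: the limit of > 1000 nM in this assay, at which 2 of the 3 values shown sit.

As far as these compounds go, how far compound 1 and compound 3 lie past their limits stays open. So does whether an amine or a carboxylic acid at this position would give a true number.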